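Aryl exchange on the shared core: cytotoxicity notes

A few compounds are considered here, and "the series" means these few. Any claim that something is new, unique, unknown or untested is made for them only; others in the source may bear on it.

Compound 1 `C=CC(=O)N1C(=O)CC(c2ccc(OC)cc2)Sc2ccccc21`: 32900 nM
Compound 2 `C=CC(=O)N1C(=O)CC(c2ccccc2Cl)Sc2ccccc21`: 33800 nM
Compound 3 `C=CC(=O)N1C(=O)CC(c2cccs2)Sc2ccccc21`: 765000 nM

In a functional assay on NB-4 cells (Homo sapiens) for cytotoxicity, read by CCK-8 assay, with a stated time of 24 h (on this read-out higher numbers stand for weaker inhibition and lower numbers for stronger inhibition), compound 3 has the highest number of the three, at 765000 nM. The next structure is compound 4 `C=CC(=O)N1C(=O)CC(c2cccc(Cl)c2)Sc2ccccc21`, with 3-chlorophenyl in place of thiophen-2-yl on a saturated ring carbon. Two large measured steps bear on this exchange, read in reverse: a 23-fold higher number from compound 1 to compound 3 (1.37 log units; beyond the scatter) and a 23-fold higher number from compound 2 to compound 3 (1.35 log units; beyond the scatter). The other aryl exchange stayed within the scatter: a 1.0-fold higher number from compound 1 to compound 2 (0.01 log units; within the scatter). Within the data shown here, no 3-chlorophenyl compound has been measured, so a large step to a lower number in this assay is expected, of similar size to those two. The estimated step is a 22-fold lower number from compound 3 to compound 4 (1.34 log units; beyond the scatter). For compound 4 the estimated value is 35000 nM, with an expected range of 12000 nM to 110000 nM.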

Compound 4, half-maximal inhibitory concentration: 31700 nM
Estimate against measurement, compound 4: 1.1-fold (0.04 log units) above; low and high end bracket the measured number.
By their numbers in this assay, from the lowest: compounds 4, 1 and 2 (each within the scatter of the next); then compound 3.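

In this assay, replacing the thiophen-2-yl group with 3-chlorophenyl gives a large step (a 24-fold lower number from compound 3 to compound 4 (1.38 log units; beyond the scatter)), so compound 3 stands alone among the four. Against the other two aryl groups, the 3-chlorophenyl compound stays within the scatter (a 1.1-fold lower number from compound 2 to compound 4 (0.03 log units; within the scatter); a 1.0-fold lower number from compound 1 to compound 4 (0.02 log units; within the scatter)), so 2-chlorophenyl, 3-chlorophenyl and 4-methoxyphenyl are not told apart here. No measured evidence accounts for the gap between thiophen-2-yl and these three groups.

Open, as far as these compounds go, is whether furan-2-yl would repeat the high number of compound 3. Also open, from the compounds shown here alone, is whether an aminophenyl or carboxyphenyl group would stay level with compound 4.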